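The compounds below may be only part of what the source reports. "The series", "measured", "known", "first", "only" and "open" are said of these compounds alone.

Compound 1 `COc1nc(-c2ccc(F)cc2)ccc1[C@@H](c1ccccc1)[C@@](O)(CCN(C)C)c1cccc2ccccc12` is the reference point of this set. In a toxicity assay on Vero cells (Chlorocebus sabaeus) for cytotoxicity (on this read-out higher numbers stand for lower toxicity in this test and lower numbers for higher toxicity in this test), compound 1 gives > 50 ug/mL, which is a limit of the assay rather than a number. Compound 2 `COc1ncc(-c2ccccc2)cc1[C@@H](c1ccccc1)[C@@](O)(CCN(C)C)c1ccccc1` also reaches a limit: in this assay compound 2 gives > 50 ug/mL. Compound 3 `COc1ncc(-c2ccccc2)cc1[C@@H](c1ccccc1)[C@@](O)(CCN(C)C)c1cccc2ccccc12` behaves the same way, and in this assay compound 3 gives > 50 ug/mL, again a limit. Within the data shown here, the single measured step, a step that the two limits leave unreadable from compound 2 to compound 3, cannot be sized because of the limit of > 50 ug/mL in this assay, at which 3 of the 3 values shown sit. Compound 4 `COc1nc(-c2cnsc2)ccc1[C@@H](c1ccccc1)[C@@](O)(CCN(C)C)c1cccc2ccccc12` carries 1,2-thiazol-4-yl in place of 4-fluorophenyl on an aromatic carbon. Among the measured compounds shown here, no measured step bears on this change, so the only guide is that every value so far sits at the limit. Compound 4 is therefore expected to stay near that limit, with a number no higher from compound 1 to compound 4 (the limit leaves the size open) estimated as no step beyond the scatter. The estimate for compound 4 is 50 ug/mL, within 25 ug/mL to 100 ug/mL.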

Compound 4, half-maximal cytotoxic concentration: 26.3 ug/mL
For compound 4 the middle estimate is 1.9-fold (0.28 log units) above the measured one; the measured number falls inside the stated range.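

Placing 1,2-thiazol-4-yl in place of 4-fluorophenyl, on the aromatic carbon next to the ring nitrogen, gives an at least 1.9-fold lower number from compound 1 to compound 4 (0.27 log units; that floor lies within the scatter) in this assay. In this assay, among these compounds, compound 4 gives 26.3 ug/mL, the only value shown that is a number and not a limit. How far the step reaches beyond its floor stays unread because of the limit: the limit of > 50 ug/mL in this assay, at which 3 of the 4 values shown sit.

As far as these compounds go, whether the ring size or the ring sulfur and nitrogen set this number remains open. From the compounds shown here alone, how a thiophen-3-yl or a pyridin-3-yl at this position reads is also open.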